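Methoxy versus hydroxy on the styryl lactone series

The source may hold more compounds than are shown below. What is called first, only, known or untested is meant among the compounds shown, and "the series" means these compounds.

Measured so far in a functional assay on HT-29 cells (Homo sapiens) for inhibition, read by sulforhodamine B assay, with a stated time of 48 h; on this read-out higher numbers stand for weaker inhibition of growth and lower numbers for stronger inhibition of growth:
compound 1 `COc1ccc(/C=C/C2(C)C=CC(=O)O2)c(OC)c1OC`: 133000 nM
compound 2 `COc1c(O)ccc(/C=C/C2(C)C=CC(=O)O2)c1OC`: 19100 nM
compound 3 `CC1(/C=C/c2ccccc2O)C=CC(=O)O1`: 31300 nM

Compound 2 and compound 1 share a core and differ in one place, (methyl in place of hydrogen on an oxygen on an aromatic ring); this change gives a 7.0-fold higher number from compound 2 to compound 1 (0.84 log units; beyond the scatter). Compound 3 sits near compound 2; the difference between the two cores is not broken down here, and their numbers lie within the usual scatter of each other, while compound 1 gives the highest number of the three, beyond the scatter from both.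

Compound 4 `COc1ccccc1/C=C/C1(C)C=CC(=O)O1` is not yet measured. It differs from compound 3 by methyl in place of hydrogen on an oxygen on an aromatic ring, which is the same kind of change as that from compound 2 to compound 1, at a place described in the same words. On that single precedent, a step of similar size is expected: in this assay the step of a 4.8-fold higher number from compound 3 to compound 4 (0.68 log units; beyond the scatter) is the estimate, beside the measured 7.0-fold higher number from compound 2 to compound 1 (0.84 log units; beyond the scatter). Among the measured compounds shown here, for compound 4 the expected value is 150000 nM, with a range of 50000 nM to 450000 nM, the width reflecting that only one earlier instance of this change is available.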

Compound 4, concentration for total growth inhibition: 30800 nM
The estimate for compound 4 lay 4.9-fold (0.69 log units) above the measured number; the measured number lies below the stated range.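

In this assay the change from hydroxy to methoxy gives a 1.0-fold lower number from compound 3 to compound 4 (0.01 log units; within the scatter) on the core of compound 3, so the larger step seen on the core of compound 2 does not carry over to this core. The size of this change therefore depends on the core that carries it, and a step read on one core is a poor guide to another in this series: the same change on two cores in this assay, a 7.0-fold higher number (0.84 log units; beyond the scatter) from compound 2 to compound 1 and a 1.0-fold lower number (0.01 log units; within the scatter) from compound 3 to compound 4, 7.1-fold (0.85 log units) apart, beyond the scatter of two such steps

Two pairs do not show which of the differences between the cores sets this gap, nor which of the two steps is the more usual one for the series.

Open, on these data alone, is how the same change behaves on further cores, since two instances that disagree give no rule for a third. Also open, as far as these compounds go, is how other groups on that aromatic oxygen or in its place would read out in this assay, for instance an ethyl or longer chain on the oxygen, an amine or a carboxylic acid.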